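From 3-methylphenyl to 4-bromophenyl on the shared core

The source may hold more compounds than are shown below. What is called first, only, known or untested is meant among the compounds shown, and "the series" means these compounds.

- Compound 1 `CN1CCN(c2ccc(Nc3ncc4nc(Nc5ccccc5)n(C5CCCCC5)c4n3)cc2)CC1`: > 5000 nM
- Compound 2 `Cc1cccc(Nc2nc3cnc(Nc4ccc(N5CCN(C)CC5)cc4)nc3n2C2CCCC2)c1`: 4700 nM

Both results come from a functional assay on HepG2 cells (Homo sapiens) for cytotoxicity, read by MTT assay, with a stated time of 72 h; a lower number here means a stronger inhibitor, a higher number a weaker inhibitor. For compound 1, the entry > 5000 nM is a limit of the assay and not a number. Among the measured compounds shown here, compound 2, at 4700 nM, therefore holds the only exact value so far. Compound 3 `CN1CCN(c2ccc(Nc3ncc4nc(Nc5ccc(Br)cc5)n(C5CCCC5)c4n3)cc2)CC1` differs from it by 4-bromophenyl in place of 3-methylphenyl on a nitrogen on an aromatic ring, with 4-bromophenyl in place of 3-methylphenyl on a nitrogen on an aromatic ring. For the measured compounds named here, no measured pair shows what such a swap does, so no shift beyond the usual scatter is expected in this assay. The estimated 1.0-fold lower number from compound 2 to compound 3 (0.02 log units; within the scatter) is correspondingly small. For compound 3, the expected value is 4500 nM, with an estimated range of 1500 nM to 10000 nM.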

Compound 3, half-maximal inhibitory concentration: > 5000 nM
Compound 3: only a limit was reported (the forecaster's own chance of this, stated with the estimate: 40%); middle value at least 1.1-fold (0.04 log units) away from the limit.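

In this assay compound 3 gives > 5000 nM and that entry is a limit of the assay, not a number. Swapping 3-methylphenyl for 4-bromophenyl on this nitrogen gives an at least 1.0-fold higher number from compound 2 to compound 3 (0.02 log units; that floor lies within the scatter) and so fixes only a lower bound for this change, the first that can be read here. The true size of the step stays hidden because the readings stop at a limit: the limit of > 5000 nM in this assay, at which 2 of the 3 values shown sit.

On these data alone, whether compound 3 lies just past that limit or far beyond it remains open. So does how an aminophenyl or carboxyphenyl group would read on this nitrogen.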